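The source may hold more compounds than are shown below. What is called first, only, known or untested is meant among the compounds shown, and "the series" means these compounds.

Among the compounds with values here, compound 1 `CC(C)(C)c1ccc(C(=O)NCc2ccc(NS(C)(=O)=O)cc2)cc1` holds the lower of the two numbers measured so far: in an assay on HeLa cells with Bile acid receptor (Homo sapiens) as the target, read by a luciferase reporter, with a stated time of 24 h (a higher number here means that more compound is needed for the effect, a lower number that less compound is needed), compound 1 gives 44 nM, while compound 2 `O=C(O)c1ccc(CNC(=O)c2ccc3ccccc3c2)cc1` gives 1360 nM, a gap well beyond the usual scatter. Compound 3 `CC(C)(C)c1ccc(C(=O)NCc2ccc(OC(F)(F)F)cc2)cc1` has not yet been measured. It differs from compound 1 only by trifluoromethoxy in place of methanesulfonamido on an aromatic carbon. Within the data shown here, no measured pair shows this change, so nothing known here tells its effect. A modest rise in the number, a small loss of potency, is expected, with the expected step being a 3.4-fold higher number from compound 1 to compound 3 (0.53 log units; beyond the scatter). Compound 3 is therefore estimated at 150 nM, likely between 40 nM and 600 nM.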

Compound 3, half-maximal effective concentration: 160 nM
Beside the measured number, compound 3's estimate is 1.1-fold (0.03 log units) below it, within the range that was stated.
By their numbers in this assay, from the lowest: compound 1; then compound 3; then compound 2.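

In this assay, within the data shown here, trifluoromethoxy in place of methanesulfonamido on this aromatic carbon gives a 3.6-fold higher number from compound 1 to compound 3 (0.56 log units; beyond the scatter) and is the first direct reading of this position. The change is modest, so a group with 0 hydrogen-bond donors at this position still leaves compound 3 at 160 nM. Nothing measured here gives a reason for the step. Going by these compounds, it remains open how an amine or a nitrile at this position would compare on the shared core, and whether this step would carry over to a different core.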